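Methoxy addition in a series tolerated at the assay limit

The source may hold more compounds than are shown below. What is called first, only, known or untested is meant among the compounds shown, and "the series" means these compounds.

compound 1 `COc1ccc(-c2nc3cc(/C(C)=N/O)ccc3[nH]2)c(OC)c1`: > 100000 nM
compound 2 `COc1ccc(-c2nc3cc(/C(C)=N/O)ccc3[nH]2)c(OC)c1OC`: > 100000 nM
compound 3 `COc1ccc(-c2nc3cc(C(C)=O)ccc3n2C2CCCCC2)cc1`: > 100000 nM

Going by the values given here, in an ADME assay on BHK-21 cells (Mesocricetus auratus) for cytotoxicity, read by MTT assay (a lower number here means that less compound is tolerated, a higher number that more compound is tolerated), every value so far is a limit of the assay rather than a number, as the limit of > 100000 nM in this assay, at which 3 of the 3 values shown sit, shows. The change from compound 1 to compound 2 is methoxy in place of hydrogen on an aromatic carbon; the step it made is a step that the two limits leave unreadable from compound 1 to compound 2. Compound 4, `COc1ccc(-c2nc3cc(C(C)=O)ccc3n2C2CCCCC2)c(OC)c1`, awaits measurement and differs from compound 3 by methoxy in place of hydrogen on an aromatic carbon, the same kind of change, though here the place is ortho to a large group and meta to a methoxy group rather than ortho to two methoxy groups and meta to a large group. The difference between the cores of compound 1 and compound 3 is not broken down here. The step from compound 3 to compound 4 is expected to be a number no higher from compound 3 to compound 4 (the limit leaves the size open) because the limit of > 100000 nM in this assay, at which 3 of the 3 values shown sit, holds for all three measured compounds. Compound 4 is estimated at 100000 nM, between 50000 nM and 200000 nM.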

Compound 4, half-maximal cytotoxic concentration: 8500 nM
Compound 4: middle estimate off by 12-fold (1.07 log units), on the high side; measured number below the stated range.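

In this assay, methoxy in place of hydrogen on an aromatic carbon, ortho to a large group and meta to a methoxy group, gives an at least 11-fold lower number from compound 3 to compound 4 (1.07 log units; beyond the scatter). The same kind of change on the core of compound 1 cannot be read, because compound 1 and compound 2 both stand at a limit of the assay rather than at a number: the limit of > 100000 nM in this assay, at which 3 of the 4 values shown sit. The large step is therefore seen on one core only, and it does not show whether the change carries over to the core of compound 1, where the methoxy also sits at a different place.

Open, on these data alone, is whether another group at the same place on the core of compound 3, such as an amine or a longer alkoxy chain, gives a step of similar size.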